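This account rests on a few compounds, and the source may have more. Where it says the series, first, only, none or still open, it means among the compounds named here.

Measured so far:
Compound 1 `Cc1cc(C)c(O)c(-n2c(N)nc3ccccc32)c1`: 476 uL/min
Compound 2 `COc1ccc(-n2c(N)nc3ccccc32)c(O)c1`: 271 uL/min

In an ADME assay on microsomes from liver (Mus musculus) for metabolic stability, read by LC-MS, using NADPH, with a stated time of 60 min, tested at 1 uM (on this read-out lower numbers stand for slow clearance and higher numbers for fast clearance), compound 2 gives 271 uL/min, the lowest of the two numbers, yet compound 1 with 476 uL/min lies within the scatter of it, so the two cannot be told apart. Compound 3 `Nc1nc2ccccc2n1-c1ccccc1O` differs from compound 2 in one place: hydrogen in place of methoxy on an aromatic carbon. Among the measured compounds shown here, no measured pair shows a change of this kind, so the data give no direction for it. The expected step is a 1.1-fold higher number from compound 2 to compound 3 (0.04 log units; within the scatter), within the scatter. Compound 3 is therefore expected to give 300 uL/min, in a range from 150 uL/min to 600 uL/min.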

Compound 3, intrinsic clearance in a liver preparation (reported as CLH), per the amount of preparation that the assay uses in the Mus musculus assay: 22 uL/min
Compound 3: middle estimate off by 14-fold (1.13 log units), on the high side, outside the stated range (below it).
By their numbers in the Mus musculus assay, from the lowest: compound 3; then compounds 2 and 1 (each within the scatter of the next).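

Among the compounds shown here, in the Mus musculus assay, hydrogen in place of methoxy on the aromatic carbon para to the large group gives a 12-fold lower number from compound 2 to compound 3 (1.09 log units; beyond the scatter), so this is the first sign that the read-out responds strongly to what sits at this place. In a physicochemical assay for solubility, read by nephelometry, measured as kinetic solubility, with a stated time of 30 min, at pH 2 (on this read-out higher numbers stand for higher solubility and lower numbers for lower solubility), compound 2 gives > 100 ug/mL, which is a limit of the assay. In the physicochemical assay, compound 3 gives > 100 ug/mL, again a limit, and no step can be read because both values sit there: the limit of > 100 ug/mL in the physicochemical assay, at which 2 of the 2 values shown sit.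

The compounds shown leave open whether only methoxy carries this large step. A fluorine or an ethoxy group at the same place could show whether the number stays close to that of compound 2 or of compound 3.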